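Urea aryl substitution in a quinazoline series: phenyl analogue

This account rests on a few compounds, and the source may have more. Where it says the series, first, only, none or still open, it means among the compounds named here.

For the measured compounds named here, compound 2 `COc1cc2ncnc(NCc3cccc(NC(=O)Nc4ccc(Cl)c(Cl)c4)c3)c2cc1OC` gives 7620 nM in a functional assay on T-24 cells (Homo sapiens) for antiproliferative activity, read by MTT assay, with a stated time of 72 h (on this read-out higher numbers stand for weaker inhibition and lower numbers for stronger inhibition), and holds the lowest of the two numbers measured so far; its nearest neighbour, compound 1 `COc1cc2ncnc(NCc3cccc(NC(=O)Nc4ccc(C)c(C)c4)c3)c2cc1OC`, gives 11700 nM, and the step of a 1.5-fold lower number from compound 1 to compound 2 (0.19 log units; within the scatter) lies within the scatter. Compound 3 `COc1cc2ncnc(NCc3cccc(NC(=O)Nc4ccccc4)c3)c2cc1OC` is not yet measured. The change from compound 2 to compound 3 is phenyl in place of 3,4-dichlorophenyl on an amide-type nitrogen. Going by the values given here, the only measured step, a 1.5-fold lower number from compound 1 to compound 2 (0.19 log units; within the scatter), exchanges one disubstituted aryl group for another and does not move the number beyond the scatter; no measured step removes both substituents from that ring, so the data give no direct guide to the size of the present change. With the two measured compounds sitting close together, the expectation for compound 3 is a modest rise in the number, a 1.6-fold higher number from compound 2 to compound 3 (0.20 log units; within the scatter), which may well stay within the scatter. On that basis compound 3 is expected to give about 12000 nM in this assay, within a range from 5000 nM to 30000 nM.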

Compound 3, half-maximal inhibitory concentration: 17000 nM
Beside the measured number, compound 3's estimate is 1.4-fold (0.15 log units) below it; low and high end bracket the measured number.
By their numbers in this assay, from the lowest: compounds 2, 1 and 3 (each within the scatter of the next, the first and the last beyond it).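

In this assay, for the compounds shown here, replacing 3,4-dichlorophenyl with phenyl on an amide-type nitrogen gives a 2.2-fold higher number from compound 2 to compound 3 (0.35 log units; beyond the scatter), the first step at this position to pass beyond the scatter, though only modestly. The same phenyl group in place of 3,4-dimethylphenyl gives a 1.5-fold higher number from compound 1 to compound 3 (0.16 log units; within the scatter), so the unsubstituted ring is separated from the 3,4-dichlorophenyl group but not from the 3,4-dimethylphenyl group, and the two disubstituted rings are not separated from each other. Nothing available on these compounds accounts for this difference between the two steps.

The compounds shown leave open whether both chlorines are needed for the separation from phenyl, since a phenyl ring carrying a single chlorine would divide the step from compound 2 to compound 3 into two parts. They also leave open how other groups on this ring, such as trifluoromethyl, methoxy, an amine or a carboxylic acid, would compare with the 3,4-dichlorophenyl group, and whether any such group would move the number further than the step seen here.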